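Aortic series: methyl replacing the allenyl ether on the core

A few compounds are considered here, and "the series" means these few. Any claim that something is new, unique, unknown or untested is made for them only; others in the source may bear on it.

Three members of the series have numbers in a functional assay on aorta (Rattus norvegicus, strain Sprague-Dawley) for inhibition; on this read-out lower numbers stand for an effect already at smaller amounts and higher numbers for an effect only at larger amounts of compound. Compound 1 `C=C=CCOc1cc2c(c3c1C[C@@H]1[C@@H](C)CO[C@]1(C)O3)C[C@@H]1[C@@H](C)CO[C@]1(C)O2` gives 12000 nM in this assay. Compound 2 `C[C@H]1CO[C@]2(C)Oc3c(c4c(c5c3C[C@@H]3[C@@H](C)CO[C@]3(C)O5)C[C@@H]3[C@@H](C)CO[C@]3(C)O4)C[C@H]12` gives 12000 nM in this assay, and compound 3 `C#CCOc1cc2c(c3c1C[C@@H]1[C@@H](C)CO[C@]1(C)O3)C[C@@H]1[C@@H](C)CO[C@]1(C)O2` gives 23000 nM in this assay. Compound 1 thus stands level with compound 2 at the digits shown, the two together at the low end of the three numbers, and the only measured step, a 1.9-fold higher number from compound 1 to compound 3 (0.28 log units; within the scatter), stays within the scatter.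

Compound 4 `Cc1cc2c(c3c1C[C@@H]1[C@@H](C)CO[C@]1(C)O3)C[C@@H]1[C@@H](C)CO[C@]1(C)O2` is the next member, not yet measured in this assay. Against compound 1 the change is methyl in place of (buta-2,3-dien-1-yl)oxy on an aromatic carbon.

Within the data shown here, no measured step bears directly on this change: the one step, ethynyl in place of propa-1,2-dien-1-yl, alters the chain on the oxygen while keeping the ether, and it gives a 1.9-fold higher number from compound 1 to compound 3 (0.28 log units; within the scatter). Compound 2, with no such side chain at all, sits level with compound 1. Removal of the whole (buta-2,3-dien-1-yl)oxy group for a methyl is therefore expected to leave the number near that of compound 1, with the wider range reflecting the lack of a closer precedent.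

The estimate for compound 4 in this assay is 15000 nM, with a range from 6000 nM to 40000 nM, which is an expected step of a 1.3-fold higher number from compound 1 to compound 4 (0.10 log units; within the scatter).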

Compound 4, half-maximal effective concentration: 40000 nM
Beside the measured number, compound 4's estimate is 2.7-fold (0.43 log units) below it, and the stated range covers the measured number.
By their numbers in this assay, from the lowest: compounds 1, 2, 3 and 4 (each within the scatter of the next, the first and the last beyond it).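

In this assay, this aromatic carbon, ortho to a fused ring, now shows a change that clears the scatter: replacing (buta-2,3-dien-1-yl)oxy with methyl gives a 3.3-fold higher number from compound 1 to compound 4 (0.52 log units; beyond the scatter). The separation depends on the reference, since the replacement of propargyloxy by methyl gives a 1.7-fold higher number from compound 3 to compound 4 (0.24 log units; within the scatter), which stays within the scatter. The substituent on this carbon can therefore shift the read-out modestly, but among these ethers the effect is resolved only from the (buta-2,3-dien-1-yl)oxy side, and no supporting data are available to explain the shift.

The compounds shown leave open whether the difference follows the ether oxygen or the unsaturated chain attached to it, a question that a methoxy or hydroxyl group on the same aromatic carbon would help separate from the methyl result. They also leave open how a saturated longer chain such as butoxy, or a basic amine carried on an ether chain, would read at this position.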